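This account rests on a few compounds, and the source may have more. Where it says the series, first, only, none or still open, it means among the compounds named here.

Compound 1 `CNCCN1CCCC1`: 1900 nM
Compound 2 `NCC(=O)NCc1cccnc1Oc1ccc(F)cc1F`: "not active" (no number reported)
Compound 3 `CNCC(=O)NCc1cccnc1Oc1ccc(F)cc1F`: "not active" (no number reported)

The read-out throughout is an assay on isolated protein for inhibition of protein arginine N-methyltransferase 6 (Homo sapiens); a higher number here means a weaker inhibitor, a lower number a stronger inhibitor. Compound 1 is the only one of the three with a number, and in this assay compound 1 gives 1900 nM. Compound 3 has no number at all: in this assay compound 3 is reported as "not active" (no number reported). The same is true of compound 2, which in this assay is reported as "not active" (no number reported). So compound 3 stands at the bottom of what is shown, with no measured strength to build on.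

Compound 4 `CC(C)(N)C(=O)NCc1cccnc1Oc1ccc(F)cc1F` differs from compound 3 in one place: 1-amino-1-methylethyl in place of (methylamino)methyl on a carbonyl carbon. Among the measured compounds shown here, no step between two measured compounds is on record for this kind of change, so the size of its effect is unknown. With compound 3 inactive, the most likely outcome is that compound 4 also returns no number, and any number that does appear is expected to be weak. On that basis the estimate for compound 4 in this assay is 40000 nM, within a range from 8000 nM to 200000 nM.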

Compound 4, half-maximal inhibitory concentration: "not active" (no number reported)
Compound 4: no number reported; there is nothing to compare the estimate with.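

Compound 4, like compound 3, is reported in this assay without a number, so no step can be read between them, and no measured evidence bears on this result. The compounds shown leave open whether 1-amino-1-methylethyl in place of (methylamino)methyl changes inhibitor strength at all.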